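Isopropoxy for Methoxy: Expecting Compound 4 from Compound 2

The source may report more compounds than this note shows. Statements on the series, on what has been measured and on what is new or still open speak of the compounds shown alone.

Three compounds have been measured in a functional assay on HepG2 cells (Homo sapiens) for antiproliferative activity, read by MTT assay, with a stated time of 48 h; on this read-out higher numbers stand for weaker inhibition and lower numbers for stronger inhibition:
compound 1 `CCN1C(=O)C(=O)c2cc(-c3ccc(OC)cc3)ccc21`: 4470 nM
compound 2 `COc1ccc(CN2C(=O)C(=O)c3cc(-c4ccc(OC)cc4)ccc32)cc1`: 50 nM
compound 3 `COc1ccc(-c2ccc3c(c2)C(=O)C(=O)N3Cc2ccc(C#N)cc2)cc1`: 1000 nM

Compound 2 stands lowest of the three. Its nearest neighbour is reached by a 20-fold higher number from compound 2 to compound 3 (1.30 log units; beyond the scatter), its furthest by an 89-fold lower number from compound 1 to compound 2 (1.95 log units; beyond the scatter).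

Compound 4 `COc1ccc(CN2C(=O)C(=O)c3cc(-c4ccc(OC(C)C)cc4)ccc32)cc1` differs from compound 2 by isopropyl in place of methyl on an oxygen on an aromatic ring. Going by the values given here, none of the measured steps touches this oxygen: an 89-fold lower number from compound 1 to compound 2 (1.95 log units; beyond the scatter), a 4.5-fold lower number from compound 1 to compound 3 (0.65 log units; beyond the scatter) and a 20-fold higher number from compound 2 to compound 3 (1.30 log units; beyond the scatter) all concern the group on the saturated chain carbon bound to the amide-type nitrogen in the ring. Among the compounds with values here, no measured step therefore bears on this change, and the step expected is a 1.6-fold higher number from compound 2 to compound 4 (0.20 log units; within the scatter), probably within the scatter in either direction. Compound 4 is estimated at 80 nM, in a range from 25 nM to 300 nM.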

Compound 4, half-maximal inhibitory concentration: > 10000 nM
Compound 4 was reported as a limit; the forecaster's own chance of this, stated with the estimate: 3%; middle value at least 120-fold (2.09 log units) from the limit.
By their numbers in this assay, from the lowest: compound 2; then compound 3; then compound 1. At a limit, above all of these: compound 4.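

In this assay, compound 4 is reported only as a limit: the limit of > 10000 nM in this assay, at which 1 of the 4 values shown sits. With an at least 200-fold higher number from compound 2 to compound 4 (2.30 log units; beyond the scatter), the oxygen on the aromatic ring proves far from indifferent: isopropyl in place of methyl, a change in this one place, is enough to produce a large step. The earlier steps had shown such movement only for the group on the saturated chain carbon.

On these data alone, the true number for compound 4 stays unknown beyond its limit. As far as these compounds go, whether ethyl or a hydroxyl group, with hydrogen in place of methyl on this oxygen, would stay close to compound 2 remains open.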